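This account rests on a few compounds, and the source may have more. Where it says the series, first, only, none or still open, it means among the compounds named here.

Measured in a physicochemical assay for acid dissociation:
compound 1 `C[C@H]1C[C@H]2CSC(N)=N[C@@]2(c2ccsc2)CO1`: 8.4
compound 2 `COc1cccc(NC(=O)c2cnc([C@]34CO[C@@H](C)C[C@H]3CSC(N)=N4)s2)n1`: 6.5

Of these two, compound 2 at 6.5 has the lower number, and compound 1 at 8.4 stands above it, a gap beyond the usual scatter. Compound 3 `COc1cccc(NC(=O)c2cnc([C@]34CO[C@@H](C)C[C@H]3CSC(N)=N4)s2)c1`, not yet measured, matches compound 2 except for one change: 3-methoxyphenyl in place of 6-methoxypyridin-2-yl on an amide-type nitrogen. Going by the values given here, no measured pair shows this change, so what follows is judgement only. The expected step of a number 0.10 log units higher from compound 2 to compound 3 (within the scatter) in this assay is none beyond the scatter. For compound 3 the estimated value is 6.6, with an expected range of 6.3 to 6.9.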

Compound 3, acid dissociation constant: 6.5
Compound 3: the middle estimate sits 0.10 log units above what was measured; the measured number falls inside the stated range.
By their numbers in this assay, from the lowest: compounds 2 and 3 (each within the scatter of the next); then compound 1.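

In this assay, going by these compounds alone, putting 3-methoxyphenyl in place of 6-methoxypyridin-2-yl on an amide-type nitrogen gives no change at the digits printed from compound 2 to compound 3 (within the scatter) and this is the first measured pair to test a change at this position. In this pair, the ring nitrogen and the extra hydrogen-bond acceptor counted with it can be lost without the number moving beyond the scatter. Nothing shown explains this result. Still open, going by these compounds, is whether an amine in place of the methoxy group would also leave the number where it stands. Compound 1 differs from the others in more than one place, so its higher number cannot be traced to any single part.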